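The compounds below may be only part of what the source reports. "The series", "measured", "known", "first", "only" and "open" are said of these compounds alone.

Measured so far in an assay on isolated protein for inhibition of thyroid hormone receptor beta (Homo sapiens), read by fluorescence polarization; a higher number here means a weaker inhibitor, a lower number a stronger inhibitor:

compound 1, `CS(=O)(=O)c1ccc(C(=O)N2CCC(C(=O)N3CCN(c4ccc(F)cc4)CC3)CC2)cc1[N+](=O)[O-]`: > 60000 nM
compound 2, `CC(C)N(C(=O)CCNC(=O)c1ccc(S(C)(=O)=O)c([N+](=O)[O-])c1)C(C)C`: > 60000 nM

The value for compound 1 is a limit of the assay, not a number. The value for compound 2 is likewise a limit. Every measured value here sits at the limit of > 60000 nM in this assay, at which 2 of the 2 values shown sit, so compound 1 cannot be placed above or below any other compound; all that is known is that no inhibition was seen up to the limit.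

Compound 3, `CN1CCN(C(=O)C2CCN(C(=O)c3ccc(S(C)(=O)=O)c([N+](=O)[O-])c3)CC2)CC1`, differs from compound 1 in one place: methyl in place of 4-fluorophenyl on an amine nitrogen in a ring. The piperazine ring and the rest of the shared core stay the same.

Going by the values given here, no measured pair of compounds differs in this way, so the size of such a step has not been observed. With only limits for both measured compounds, the expectation is a step that the limit leaves unreadable from compound 1 to compound 3, meaning no step beyond the scatter in either direction. Compound 3 is therefore estimated at 80000 nM, within a range from 20000 nM to 300000 nM, and the outcome is expected most likely to be another limit rather than a number.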

Compound 3, half-maximal inhibitory concentration: > 60000 nM
Compound 3: a limit, no number (the forecaster's own chance of this, stated with the estimate: 75%); the middle value lies beyond the limit too.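

Compound 1 and compound 3 each give only a limit and not a number, so no step can be read for methyl in place of 4-fluorophenyl: the limit of > 60000 nM in this assay, at which 3 of the 3 values shown sit. The compounds shown leave open whether this change has any effect on inhibition, and what structure would give a measurable value.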